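Adding a 3-methoxyphenyl group to compound 3

The source may report more compounds than this note shows. Statements on the series, on what has been measured and on what is new or still open speak of the compounds shown alone.

In a functional assay on NCI-H460 cells (Homo sapiens) for cytotoxicity, read by MTT assay, with a stated time of 68 h (a lower number here means a stronger inhibitor, a higher number a weaker inhibitor), the measured compounds give these values:
- Compound 1 `Nc1cccc(-c2cccc(NC(=O)C(Cl)Cl)c2)c1` gives > 50000 nM (a limit)
- Compound 2 `O=C(Nc1cccc(-c2cccc(F)c2)c1)C(Cl)Cl` gives > 50000 nM (a limit)
- Compound 3 `COc1cccc(-c2cccc(NC(=O)C(Cl)Cl)c2)c1` gives 33800 nM

Among the measured compounds shown here, compound 3 holds the only actual number here, the other two values being limits: the limit of > 50000 nM in this assay, at which 2 of the 3 values shown sit. Compound 4 `COc1cccc(-c2cc(NC(=O)C(Cl)Cl)cc(-c3cccc(OC)c3)c2)c1` differs from compound 3 by 3-methoxyphenyl in place of hydrogen on an aromatic carbon. For the measured compounds named here, two measured steps bear on this, an at least 1.4-fold lower number from compound 1 to compound 3 (0.17 log units; that floor lies within the scatter) and an at least 1.4-fold lower number from compound 2 to compound 3 (0.17 log units; that floor lies within the scatter). Both are exchanges rather than additions, so they guide the estimate only loosely. A modest move to a lower number in this assay is expected, since the entering group also carries a methoxy, as compound 3 does at 33800 nM. The expected step is a 3.4-fold lower number from compound 3 to compound 4 (0.53 log units; beyond the scatter). For compound 4 the estimated value is 10000 nM, with an expected range of 2500 nM to 40000 nM.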

Compound 4, half-maximal inhibitory concentration: > 30000 nM
Compound 4 ended at the assay's limit; the forecaster's own chance of this, stated with the estimate: 15%; middle value at least 3.0-fold (0.47 log units) away from the limit.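

In this assay compound 4 gives > 30000 nM as a limit and not a number, so the step from compound 3 to compound 4 cannot be read. The compounds shown leave open whether 3-methoxyphenyl in place of hydrogen changes the number at all.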